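The source may hold more compounds than are shown below. What is called first, only, known or untested is meant among the compounds shown, and "the series" means these compounds.

Within the data shown here, in a functional assay on LoVo cells (Homo sapiens) for cytotoxicity, read by MTT assay, with a stated time of 72 h (a lower number here means a stronger inhibitor, a higher number a weaker inhibitor), compound 1 `c1ccc2[nH]c(-n3cccn3)cc2c1` gives 86000 nM and stands highest of the two numbers so far. Compound 2 `COc1ccc2[nH]c3c(c4c(n5cccc35)C(=O)N(C)C4=O)c2c1` gives 40000 nM as the lower number, a gap beyond the usual scatter. Compound 3 `Cc1ccc2[nH]c(-n3cccn3)cc2c1` differs from compound 1 by methyl in place of hydrogen on an aromatic carbon in one place, methyl in place of hydrogen on an aromatic carbon. Among the measured compounds shown here, no measured pair shows this change, so in this assay only a small step towards stronger inhibition is expected, probably not beyond the scatter. The estimated step is a 1.2-fold lower number from compound 1 to compound 3 (0.09 log units; within the scatter) at the middle of the estimate. For compound 3 a value of 70000 nM is expected, with an estimated range from 30000 nM to 150000 nM around it.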

Compound 3, half-maximal inhibitory concentration: 87000 nM
Compound 3: middle estimate off by 1.2-fold (0.09 log units), on the low side; the measured number falls inside the stated range.
By their numbers in this assay, from the lowest: compound 2; then compounds 1 and 3 (each within the scatter of the next).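

In this assay, among these compounds, the first single-place comparison on the core of compound 1 gives a 1.0-fold higher number from compound 1 to compound 3 (0.01 log units; within the scatter) for methyl in place of hydrogen on an aromatic carbon of the six-membered ring. At this position, then, the methyl group leaves the two compounds indistinguishable in this assay. Going by these compounds, whether an amine, a carboxylic acid or a longer chain on this carbon would separate from compound 1 stays open, as does the effect of methyl on other carbons of the core. No measurement given here offers an explanation for this result.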